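A few compounds are considered here, and "the series" means these few. Any claim that something is new, unique, unknown or untested is made for them only; others in the source may bear on it.

Compound 1 `COc1ccc(C(=O)/C=C/c2ccc(OCc3cn(Cc4cccc(Br)c4)nn3)cc2)cc1` gives 50% in a functional assay on MIA PaCa-2 cells (Homo sapiens) for inhibition, read by MTT assay, with a stated time of 48 h, tested at 10 uM; a lower number here means less inhibition of growth, a higher number more inhibition of growth at the concentration tested; compound 2 `COc1ccc(C(=O)/C=C/c2ccc(OCc3cn(Cc4ccc(Br)cc4)nn3)cc2)cc1` gives 56% in this assay.

Compound 2 holds the higher of the two numbers, but the step of a number 6 percentage points higher from compound 1 to compound 2 (within the scatter) is within the scatter, so the two stand level. Compound 3 `COc1ccc(C(=O)/C=C/c2ccc(OCc3cn(Cc4cccc(F)c4)nn3)cc2)cc1` differs from compound 2 by 3-fluorophenyl in place of 4-bromophenyl on a saturated chain carbon bound to an aromatic nitrogen. For the measured compounds named here, no measured step changes a halogen type; the one step on this benzyl group, a number 6 percentage points higher from compound 1 to compound 2 (within the scatter), moves the position only and stays within the scatter. For compound 3 a step of a number 6 percentage points lower from compound 2 to compound 3 (within the scatter) is therefore expected, not beyond the scatter. Compound 3 is estimated at 50%, within 35% to 65%.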

Compound 3, percent growth inhibition at one concentration: 48%
Compound 3: middle estimate off by 2 percentage points, on the high side; measured number inside the range.
By their numbers in this assay, from the lowest: compounds 3, 1 and 2 (each within the scatter of the next).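

For the compounds shown here, the change of fluoro in place of bromo on an aromatic carbon, a number 2 percentage points lower from compound 1 to compound 3 (within the scatter), gives the first halogen comparison on this benzyl group in this assay. The step that alters halogen and position together, a number 8 percentage points lower from compound 2 to compound 3 (within the scatter), also stays within the scatter, so 3-bromophenyl, 4-bromophenyl and 3-fluorophenyl stand level at this place. Nothing measured offers an explanation for these steps.

Only halogen-bearing phenyl groups are shown on this saturated chain carbon. As far as these compounds go, whether an amine, a carboxylic acid or a longer chain there would separate from these three remains open.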